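The source may report more compounds than this note shows. Statements on the series, on what has been measured and on what is new or still open speak of the compounds shown alone.

Measured compounds:
compound 1 `CCOc1cc(C(C)(C)C)ccc1C1=NC(c2ccc(Cl)cc2)C(c2ccc(Cl)cc2)N1C(=O)N1CCN(Cc2ccc(C(=O)NO)cc2)CC1`: 2030 nM
compound 2 `CCOc1cc(C(C)(C)C)ccc1C1=NC(c2ccc(Cl)cc2)C(c2ccc(Cl)cc2)N1C(=O)NCCCCCCCC(=O)Nc1ccccc1N`: 9910 nM
compound 3 `CCOc1cc(C(C)(C)C)ccc1C1=NC(c2ccc(Cl)cc2)C(c2ccc(Cl)cc2)N1C(=O)N1CCN(CCCCC(=O)NO)CC1`: 5210 nM

All three were run in a functional assay on HCT-116 cells (Homo sapiens) for antiproliferative activity, read by CCK-8 assay, with a stated time of 72 h; a higher number here means a weaker inhibitor, a lower number a stronger inhibitor. Compound 3 holds the second highest number of the three; compound 2 is within the scatter of it, while compound 1 sits a 2.6-fold higher number from compound 1 to compound 3 (0.41 log units; beyond the scatter) away. Compound 4 `CCOc1cc(C(C)(C)C)ccc1C1=NC(c2ccc(Cl)cc2)C(c2ccc(Cl)cc2)N1C(=O)N1CCN(c2ncc(C(=O)NO)cn2)CC1` is not yet measured. It differs from compound 3 as follows: 5-(hydroxycarbamoyl)pyrimidin-2-yl in place of 4-(hydroxycarbamoyl)butyl on an amine nitrogen in a ring. For the measured compounds named here, the one measured step that bears on this is the exchange of an aryl-borne hydroxamate for a chain-borne one, which gave a 2.6-fold higher number from compound 1 to compound 3 (0.41 log units; beyond the scatter). Since compound 4 again carries its hydroxamate on an aromatic ring, the number is expected to move back down, by about a 2.1-fold lower number from compound 3 to compound 4 (0.32 log units; beyond the scatter). Compound 4 is therefore estimated at 2500 nM, with a range of 1000 nM to 7000 nM.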

Compound 4, half-maximal inhibitory concentration: 980 nM
Compound 4: middle estimate off by 2.6-fold (0.41 log units), on the high side, outside the stated range (below it).
By their numbers in this assay, from the lowest: compound 4; then compound 1; then compounds 3 and 2 (each within the scatter of the next).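

On the amine nitrogen in the six-membered ring, 5-(hydroxycarbamoyl)pyrimidin-2-yl improves on both earlier hydroxamate groups in this assay, with a 5.3-fold lower number from compound 3 to compound 4 (0.73 log units; beyond the scatter) against 4-(hydroxycarbamoyl)butyl and a 2.1-fold lower number from compound 1 to compound 4 (0.32 log units; beyond the scatter) against 4-(hydroxycarbamoyl)benzyl. The earlier compounds shown here ranked only a benzyl group against a chain, whereas this result shows that the benzyl group is not the best of the hydroxamate carriers at this position. No measurement available here accounts for either gain.

The change from compound 1 to compound 4 alters both the ring and the benzyl methylene, so the two contributions remain unseparated. A 4-(hydroxycarbamoyl)phenyl group on the same nitrogen would divide them.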